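Ethyl for cyclopentyl on a piperazine of a TLR9 antagonist

The source may report more compounds than this note shows. Statements on the series, on what has been measured and on what is new or still open speak of the compounds shown alone.

Compound 1 `CCN1CCN(CCCn2cnc3c(N4CCN(CC)CC4)ncnc32)CC1`: 1190 nM
Compound 2 `CCN1CCN(c2nc(NCc3ccc(F)cc3)nc3c2ncn3CCCN2CCCC2)CC1`: 40 nM
Compound 3 `CCN1CCN(CCCn2cnc3c(N4CCN(C5CCCC5)CC4)nc(NCc4ccc(F)cc4)nc32)CC1`: 250 nM

In an assay on HEK293 cells for antagonist activity at Toll-like receptor 9 (Homo sapiens), read by spectrophotometry (on this read-out higher numbers stand for weaker inhibition and lower numbers for stronger inhibition), compound 3 gives 250 nM, the second highest of the three numbers. Its nearest neighbour is compound 1, whose value in this assay is higher by a margin beyond the scatter; compound 2, with the lowest number of the set, lies further away in the other direction, again beyond the scatter.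

Compound 4 `CCN1CCN(CCCn2cnc3c(N4CCN(CC)CC4)nc(NCc4ccc(F)cc4)nc32)CC1` has not been measured in this assay. It differs from compound 3 in one place: ethyl in place of cyclopentyl on an amine nitrogen in a ring. For the measured compounds named here, no measured pair shows exactly this exchange, so its size cannot be read from the data. Compound 2 carries the same ethyl-bearing piperazine and gives 40 nM, which shows that this smaller group is compatible with a low number. The step from compound 3 to compound 4 is therefore expected to be modest, a 1.7-fold lower number from compound 3 to compound 4 (0.22 log units; within the scatter), most likely toward a lower number or none beyond the scatter. Compound 4 is estimated at 150 nM, within a range of 50 nM to 500 nM.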

Compound 4, half-maximal inhibitory concentration: 470 nM
The estimate for compound 4 lay 3.1-fold (0.50 log units) below the measured number; low and high end bracket the measured number.
By their numbers in this assay, from the lowest: compound 2; then compounds 3 and 4 (each within the scatter of the next); then compound 1.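

In this assay, ethyl in place of cyclopentyl on an amine nitrogen in a ring gives a 1.9-fold higher number from compound 3 to compound 4 (0.27 log units; within the scatter), so this position tolerates both groups within the scatter. Adding the (4-fluorobenzyl)amino group in place of hydrogen on an aromatic carbon gives a 2.5-fold lower number from compound 1 to compound 4 (0.40 log units; beyond the scatter), a modest step beyond the scatter. The large step lies at the end of the chain, where 4-ethylpiperazin-1-yl in place of pyrrolidin-1-yl gives a 12-fold higher number from compound 2 to compound 4 (1.07 log units; beyond the scatter), which shows that the number responds strongly to this change on a saturated chain carbon, three bonds along the chain from an aromatic nitrogen.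

Nothing at hand explains any of these steps. On these data alone, it remains open how a hydrogen or an acetyl group on the same ring nitrogen, or a piperidin-1-yl group at the chain end, would read.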